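This account rests on a few compounds, and the source may have more. Where it says the series, first, only, none or still open, it means among the compounds named here.

Measured so far in a physicochemical assay for solubility, in phosphate buffer, measured as kinetic solubility, with a stated time of 1 h, at pH 7.4; on this read-out lower numbers stand for lower solubility and higher numbers for higher solubility:
compound 1, `CC(C)N1C(=O)CN(Cc2ccc(-c3ccc(CC(=O)O)cc3)cn2)C1=O`, gives 108 ug/mL;
compound 2, `O=C1CN(Cc2ccc(-c3ccc(C4(C(=O)O)CC4)cc3)cc2)C(=O)N1c1ccccc1`, gives 195 ug/mL;
compound 3, `O=C(O)Cc1ccccc1-c1cccc(NC(=O)OCc2ccccc2)c1`, gives 287 ug/mL.

Compound 2 stands second highest of these three numbers, but its gaps to compound 3 and to compound 1 both lie within the usual scatter, so the three values cannot be told apart with confidence. Compound 4, `O=C1CN(Cc2ccc(-c3ccccc3)cc2)C(=O)N1c1ccccc1`, has not yet been measured in this assay. Its structure differs from compound 2 in one place: hydrogen in place of 1-carboxycyclopropyl on an aromatic carbon. Among the compounds with values here, no measured pair shows this change, so the size of the step is not known from these data; the expectation here is a large drop well beyond the scatter. Compound 4 is estimated at 5 ug/mL, with a range from 1 ug/mL to 30 ug/mL, an expected step of a 39-fold lower number from compound 2 to compound 4 (1.59 log units; beyond the scatter).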

Compound 4, solubility: 7.5 ug/mL
The estimate for compound 4 lay 1.5-fold (0.18 log units) below the measured number; the measured number falls inside the stated range.
By their numbers in this assay, from the lowest: compound 4; then compounds 1, 2 and 3 (each within the scatter of the next, the first and the last beyond it).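

At the position para to a large group, in this assay, hydrogen in place of 1-carboxycyclopropyl gives a 26-fold lower number from compound 2 to compound 4 (1.41 log units; beyond the scatter) as the first step measured between two compounds that differ in one place. Within the data shown here, the earlier compounds offered no such pair, so this is the first sign that a single change on this aromatic carbon can move the number by a large step. Nothing measured here accounts for the size of this step.

The pair cannot separate the three-membered ring from the carboxylic acid it carries, since both leave together. From the compounds shown here alone, whether a plain carboxylic acid, an amine or a hydroxyl at this place would give a number nearer compound 2 or compound 4 stays open.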